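From tert-butyl amide to dimethyl amide

A few compounds are considered here, and "the series" means these few. Any claim that something is new, unique, unknown or untested is made for them only; others in the source may bear on it.

compound 1 `COc1cc(Cl)c(-c2nc(SCC(=O)NC(C)C)nc3[nH]cc(C#N)c23)cc1O` gives 178 nM
compound 2 `COc1cc(Cl)c(-c2nc(SCC(=O)NC(C)(C)C)nc3[nH]cc(C#N)c23)cc1O` gives 152 nM
compound 3 `COc1cc(Cl)c(-c2nc(SCC(=O)NC(C)(C)C)nc3[nH]cc(C#N)c23)cc1OC` gives 84 nM

All three were tested in a functional assay on MDA-MB-468 cells (Homo sapiens) for antiproliferative activity, read by sulforhodamine B assay, with a stated time of 4 days (on this read-out lower numbers stand for stronger inhibition of growth and higher numbers for weaker inhibition of growth), and compared on that read-out. There compound 2 at 152 nM lies within the scatter of both compound 1 and compound 3. Compound 4 `COc1cc(Cl)c(-c2nc(SCC(=O)N(C)C)nc3[nH]cc(C#N)c23)cc1O` has dimethylamino in place of (tert-butyl)amino on a carbonyl carbon and is still unmeasured. The closest evidence is a 1.2-fold lower number from compound 1 to compound 2 (0.07 log units; within the scatter) for a change in that same amino group. The other step, a 1.8-fold lower number from compound 2 to compound 3 (0.26 log units; within the scatter) on an oxygen on an aromatic ring, bears on it less. For the measured compounds named here, no measured compound lacks the amide hydrogen, so the expectation is loose. A slightly higher number but no step beyond the scatter is expected, and the estimated step is a 1.6-fold higher number from compound 2 to compound 4 (0.22 log units; within the scatter) in size. Compound 4 is estimated at 250 nM in this assay with 90 nM to 700 nM as the expected range.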

Compound 4, concentration for 50% growth inhibition: 23 nM
Compound 4: the middle estimate sits 11-fold (1.04 log units) above what was measured, and the stated range ends above it.
By their numbers in this assay, from the lowest: compound 4; then compounds 3, 2 and 1 (each within the scatter of the next, the first and the last beyond it).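

In this assay, the amino group on the carbonyl carbon proves far more consequential than the earlier change there showed: dimethylamino in place of (tert-butyl)amino gives a 6.6-fold lower number from compound 2 to compound 4 (0.82 log units; beyond the scatter), and dimethylamino in place of isopropylamino gives a 7.7-fold lower number from compound 1 to compound 4 (0.89 log units; beyond the scatter). Compound 4 alone lacks the amide hydrogen, and it also carries fewer heavy atoms than compound 2, so these compounds cannot separate the two differences. Nothing measured here accounts for the step. As far as these compounds go, whether methylamino or pyrrolidinyl on that carbonyl carbon would match dimethylamino remains open, as does the effect of methyl in place of hydrogen on the aromatic-ring oxygen of compound 4.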